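The source may hold more compounds than are shown below. What is called first, only, known or untested is meant among the compounds shown, and "the series" means these compounds.

Measured so far in an ADME assay on CCRF-HSB-2 cells (Homo sapiens) for cytotoxicity, with a stated time of 7 days; a lower number here means that less compound is tolerated, a higher number that more compound is tolerated:
Compound 1 `CNc1nc(N)nc2c1ncn2/C=C1/CC1(CO)CO` gives > 20000 nM, which is a limit of the assay rather than a number.
Compound 2 `CCCNc1nc(N)nc2c1ncn2/C=C1/CC1(CO)CO` gives > 20000 nM, also a limit.
Compound 3 `CCCCCCOc1nc(N)nc2c1ncn2/C=C1/CC1(CO)CO` gives > 20000 nM, also a limit.

All three values sit at one place, (the limit of > 20000 nM in this assay, at which 3 of the 3 values shown sit), so none of the steps between them can be read: a step that the two limits leave unreadable from compound 2 to compound 1, a step that the two limits leave unreadable from compound 1 to compound 3, a step that the two limits leave unreadable from compound 2 to compound 3. The change from compound 2 to compound 1 is hydrogen in place of ethyl on a saturated chain carbon bound to a nitrogen on an aromatic ring. The two cores of compound 2 and compound 3 differ by hexyloxy in place of propylamino on an aromatic carbon.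

Compound 4 `CCCCOc1nc(N)nc2c1ncn2/C=C1/CC1(CO)CO` is not yet measured; it differs from compound 3 by hydrogen in place of ethyl on a saturated chain carbon, four bonds along the chain from an oxygen on an aromatic ring. This is the same kind of change as that from compound 2 to compound 1, but not the same: there the place is a saturated chain carbon bound to a nitrogen on an aromatic ring, here a saturated chain carbon four bonds along the chain from an oxygen on an aromatic ring. Beside a step that the two limits leave unreadable from compound 2 to compound 1, the expected step that the limit leaves unreadable from compound 3 to compound 4 rests on (the limit of > 20000 nM in this assay, at which 3 of the 3 values shown sit), where every measured compound sits. Compound 4 is expected to give 30000 nM, most likely again only a limit, within 15000 nM to 100000 nM.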

Compound 4, half-maximal cytotoxic concentration: > 20000 nM
Compound 4 ended at the assay's limit; the forecaster's own chance of this, stated with the estimate: 85%; the middle value is on the limit's open side.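

In this assay, among these compounds, compound 4 gives > 20000 nM as a limit of the assay, so no step from compound 1, compound 2 or compound 3 to compound 4 can be read. The compounds shown leave open how much of each one the cells would tolerate, and whether changing the chain makes any difference.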